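A few compounds are considered here, and "the series" means these few. Any claim that something is new, unique, unknown or untested is made for them only; others in the source may bear on it.

Three compounds have been measured in a functional assay on SW480 cells (Homo sapiens) for cytotoxicity, read by MTT assay, with a stated time of 24 h; on this read-out lower numbers stand for stronger inhibition and higher numbers for weaker inhibition:

compound 1 `C=CC1=C(C(=O)NCCCCC)C(c2ccc(OC)cc2)OC1`: > 100000 nM, a limit of the assay
compound 2 `C=CC1=C(C(=O)NCCC)C(c2ccc(OC)c(OC)c2)OC1`: > 100000 nM, a limit of the assay
compound 3 `C=CC1=C(C(=O)NCCCCC)C(c2ccc(F)cc2)OC1`: > 100000 nM, a limit of the assay

Compound 1 therefore stands only at the limit, as do the other two; all three sit at the limit of > 100000 nM in this assay, at which 3 of the 3 values shown sit. Among the measured compounds shown here, the one measured step, a step that the two limits leave unreadable from compound 1 to compound 3, is unreadable, as both ends are limits. Compound 4 `C=CC1=C(C(=O)Nc2ccccc2)C(c2ccc(OC)cc2)OC1` differs from compound 1 by phenyl in place of pentyl on an amide-type nitrogen. For the measured compounds named here, no measured step concerns this change, and the steps that exist give no readable size. Compound 4 is thus expected to remain near the limit, with a step that the limit leaves unreadable from compound 1 to compound 4 no larger than the scatter. The estimate for compound 4 in this assay is 150000 nM, between 40000 nM and 600000 nM.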

Compound 4, half-maximal inhibitory concentration: > 100000 nM
Compound 4: no number, only a limit; the forecaster's own chance of this, stated with the estimate: 80%; the middle value lies beyond the limit too.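

Compound 1 and compound 4 both stand only at a limit in this assay, so no size can be read for phenyl in place of pentyl on the amide-type nitrogen. The compounds shown leave open which structure, if any, would give a measurable value: the limit of > 100000 nM in this assay, at which 4 of the 4 values shown sit.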